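A few compounds are considered here, and "the series" means these few. Any claim that something is new, unique, unknown or untested is made for them only; others in the source may bear on it.

In an in vitro ADME assay on microsomes from liver (Homo sapiens) for pharmacokinetics (a lower number here means slower removal, a higher number faster removal of the compound), compound 1 (`CC(=O)N[C@@H](CCN1C[C@@H]2CN(C(=O)c3ccccc3)C[C@@H]2C1)c1ccccc1`) gives 70 mL.min-1.g-1 and compound 2 (`O=C(O)c1cccc(C(=O)N2C[C@H]3CN(CC[C@H](NC(=O)C4CCCC4)c4ccccc4)C[C@H]3C2)c1`) gives 3 mL.min-1.g-1 as the lower of the two numbers, a gap that lies beyond the scatter. Among the compounds with values here, no measured pair differs in one place only, so no measured step speaks directly to the next change. Compound 3 (`O=C(N[C@@H](CCN1C[C@@H]2CN(C(=O)c3cccnn3)C[C@@H]2C1)c1ccccc1)C1CCCC1`) has pyridazin-3-yl in place of the 3-carboxyphenyl of compound 2 on a carbonyl carbon (pyridazin-3-yl in place of 3-carboxyphenyl on a carbonyl carbon). Within the data shown here, compound 1 at 70 mL.min-1.g-1 is the only measured compound without 3-carboxyphenyl, though it also differs from compound 2 elsewhere. On that limited basis an increase beyond the scatter is expected in this assay with a 5.0-fold higher number from compound 2 to compound 3 (0.70 log units; beyond the scatter) as the estimated step. Compound 3 is expected at 15 mL.min-1.g-1 with 5 mL.min-1.g-1 to 50 mL.min-1.g-1 as the estimated range.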

Compound 3, intrinsic clearance in microsomes: 137 mL.min-1.g-1
Beside the measured number, compound 3's estimate is 9.1-fold (0.96 log units) below it, outside the stated range (above it).
By their numbers in this assay, from the lowest: compound 2; then compounds 1 and 3 (each within the scatter of the next).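

In this assay the exchange at this position gives a 46-fold higher number from compound 2 to compound 3 (1.66 log units; beyond the scatter) with pyridazin-3-yl in place of 3-carboxyphenyl on a carbonyl carbon whose other neighbour is an amide-type nitrogen in a ring. This is the first comparison in the series that differs in one place only, so the whole step belongs to this one exchange and the position is shown to be far from silent for removal in this system. No measurement on hand bears on what lies behind the size of the step.

The exchange removes the carboxylic acid and replaces the carbon-only aromatic ring with one holding two hetero atoms in a single move, so the compounds shown do not separate these two changes. A pyridazine ring carrying a carboxylic acid, or a 3-carbamoylphenyl group, on the same carbonyl carbon would bear on that question.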